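Adding a Hydroxy Group to a Weak Cytotoxic Lead

A few compounds are considered here, and "the series" means these few. Any claim that something is new, unique, unknown or untested is made for them only; others in the source may bear on it.

This account follows a single change within a small set of phenylpiperazine propanolamines tested in an ADME assay on PNT1A cells (Homo sapiens) for cytotoxicity, read by MTT assay, with a stated time of 48 h; on this read-out higher numbers stand for weaker inhibition and lower numbers for stronger inhibition. Compound 1 `Oc1ccc(N2CCN(CC(O)COc3cccc4ccccc34)CC2)c(O)c1` gives 29900 nM in this assay. Compound 2 `COc1cc(O)ccc1N1CCN(CC(O)COc2cccc3ccccc23)CC1` differs from compound 1 by a methyl in place of a hydrogen on an aromatic oxygen, and the step of an at least 1.6-fold higher number from compound 1 to compound 2 (0.22 log units; that floor lies within the scatter) sits at the floor of its own scatter. For compound 2 this assay reports only a limit, > 50000 nM, as noted in the limit of > 50000 nM in this assay, at which 1 of the 2 values shown sits, so compound 2 stands at the edge of what the assay can resolve rather than at a number.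

Compound 3 `COc1cc(O)ccc1N1CCN(CC(O)COc2ccc(O)c3ccccc23)CC1` is the unmeasured compound. It differs from compound 2 by hydroxy in place of hydrogen on an aromatic carbon. For the measured compounds named here, none of the measured steps bears on this change: the only step in hand concerns a methyl on an oxygen, not a hydroxy on an aromatic carbon. With compound 2 already at a limit, there is nothing to place compound 3 on either side of it with confidence. Compound 3 is therefore estimated at 50000 nM, between 20000 nM and 150000 nM, which means an expected step of a number no higher from compound 2 to compound 3 (the limit leaves the size open).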

Compound 3, half-maximal inhibitory concentration: 37200 nM
Compound 3: the middle estimate sits 1.3-fold (0.13 log units) above what was measured, within the range that was stated.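

For the compounds shown here, with compound 3, hydroxy in place of hydrogen on an aromatic carbon, para to a large group, brings the series a first change on the six-membered aromatic ring that is part of the fused system, whereas the earlier step concerned only a methyl on an aromatic oxygen. In this assay this change gives an at least 1.3-fold lower number from compound 2 to compound 3 (0.12 log units; that floor lies within the scatter), so the data show that compound 3 yields a number, but they do not establish a real gain in inhibition from the added hydroxy. The true size of the step cannot be fixed, as one end of the comparison is not a number: the limit of > 50000 nM in this assay, at which 1 of the 3 values shown sits.

Going by these compounds, whether an amine or a carboxylic acid on that same aromatic carbon would read any differently in this assay remains open, as does whether a longer chain on the aromatic oxygen of compound 2 would matter once this hydroxy is present. Also open, on these data alone, is how the same hydroxy would behave on the core of compound 1, where the methyl on the aromatic oxygen is replaced by hydrogen and a number rather than a limit would serve as the starting point.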